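The source may report more compounds than this note shows. Statements on the series, on what has been measured and on what is new or still open speak of the compounds shown alone.

Of the two compounds measured in an assay on NK92 cells for inhibition of interleukin-2 (Homo sapiens), read by AlphaScreen, with stated times of 30 min and 1 h (a lower number here means a stronger inhibitor, a higher number a weaker inhibitor), compound 2 `Cn1nc(Cc2nnc(SCCCCCCCC(=O)Nc3ccc(Cl)cc3Cl)n2CCC=O)c2ccccc2c1=O` gives the lower number, 960 nM, while compound 1 `Cn1c(Cc2nn(C)c(=O)c3ccccc23)nnc1SCC(=O)Nc1ccc(Cl)cc1Cl` gives 7700 nM, a gap beyond the scatter. Compound 3 `Cn1nc(Cc2nnc(SCCCCCCCC(=O)Nc3ccc(Cl)cc3Cl)n2CCC(=O)O)c2ccccc2c1=O` has not yet been measured; it differs from compound 2 by hydroxy in place of hydrogen on a carbonyl carbon, which one bond further out reads formyl to carboxy. Among the measured compounds shown here, no comparable step between measured compounds is known, so the expected step is a 1.0-fold higher number from compound 2 to compound 3 (0.02 log units; within the scatter), with no direction favoured and nothing expected beyond the scatter. Compound 3 is therefore estimated at 1000 nM, with a range from 400 nM to 2500 nM.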

Compound 3, half-maximal inhibitory concentration: 14300 nM
Compound 3: the middle estimate sits 14-fold (1.16 log units) below what was measured, and the stated range ends below it.
By their numbers in this assay, from the lowest: compound 2; then compounds 1 and 3 (each within the scatter of the next).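

In this assay, hydroxy in place of hydrogen on this carbonyl carbon gives a 15-fold higher number from compound 2 to compound 3 (1.17 log units; beyond the scatter), a large weakening. Among the compounds shown here, this shows that the change from 2-formylethyl to 2-carboxyethyl is not silent and that the assay responds to what this carbonyl carbon carries, which the earlier compounds could not show, as no step linked them.

From the compounds shown here alone, whether a methyl ester, a primary amide or an alcohol in this place would read closer to compound 2 or to compound 3 remains open. Nothing available accounts for the size of this step.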